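The source may report more compounds than this note shows. Statements on the series, on what has been measured and on what is new or still open speak of the compounds shown alone.

Compound 2 `O=C(N1CCCCC1COc1ccccc1)n1ncc(C(O)(c2ccc(F)cc2)c2ccc(F)cc2)n1` shares its core with compound 1 `O=C(N1CCCCC1COc1ccc(F)cc1)n1ncc(C(O)(c2ccc(F)cc2)c2ccc(F)cc2)n1`; in an assay on isolated protein for inhibition of Monoacylglycerol lipase ABHD6 (Homo sapiens), read by fluorescence (on this read-out higher numbers stand for weaker inhibition and lower numbers for stronger inhibition), compound 1 gives 200 nM and compound 2 gives 200 nM, the step of no change at the digits printed from compound 1 to compound 2 (within the scatter) being hydrogen in place of fluoro on an aromatic carbon. Compound 3 `O=C(N1CCCCC1Cc1ccccc1)n1ncc(C(O)(c2ccc(F)cc2)c2ccc(F)cc2)n1` differs from compound 2 by phenyl in place of phenoxy on a saturated chain carbon bound to a saturated ring carbon. For the measured compounds named here, no measured step touches the linker between the saturated ring and the aromatic ring, so the only measured step, from compound 1 to compound 2, does not bear on this change. Compound 3 is therefore expected to give roughly 300 nM, within 80 nM to 1200 nM, a step of a 1.5-fold higher number from compound 2 to compound 3 (0.18 log units; within the scatter) that is estimated with wide uncertainty.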

Compound 3, half-maximal inhibitory concentration: 25.1 nM
Beside the measured number, compound 3's estimate is 12-fold (1.08 log units) above it; the measured number lies below the stated range.
By their numbers in this assay, from the lowest: compound 3; then compounds 1 and 2 (each within the scatter of the next).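

In this assay the group on the saturated chain carbon bound to a saturated ring carbon proves to matter: phenyl in place of phenoxy gives an 8.0-fold lower number from compound 2 to compound 3 (0.90 log units; beyond the scatter) and phenyl in place of 4-fluorophenoxy gives an 8.0-fold lower number from compound 1 to compound 3 (0.90 log units; beyond the scatter). The fluoro on the phenoxy group had shown no such response, so the change that counts here is the swap to phenyl. No evidence at hand accounts for this step. Going by these compounds, whether an amine in place of the phenoxy oxygen or a longer chain such as phenethyl would hold this level stays open, as does the effect of a fluoro on the phenyl of compound 3.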